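The source may hold more compounds than are shown below. What is called first, only, known or untested is meant among the compounds shown, and "the series" means these compounds.

Of the compounds shown here, three built on one shared core have been tested in a functional assay on NCI-H226 cells (Homo sapiens) for inhibition, read by sulforhodamine B assay, with a stated time of 48 h, tested at 10 uM; on this read-out higher numbers stand for more inhibition at the one concentration tested (going by the name of the read-out) and lower numbers for less inhibition. Compound 1 `O=Cc1ccc(-c2cn3ccnc3c(-c3ccc4ncn(C5CCCCC5)c4c3)n2)cc1` carries a formyl group and gives 0.53%. Compound 2 `Fc1ccc(-c2cn3ccnc3c(-c3ccc4ncn(C5CCCCC5)c4c3)n2)cc1`, with fluoro in place of formyl on an aromatic carbon, gives 23.3%, and compound 3 `Brc1ccc(-c2cn3ccnc3c(-c3ccc4ncn(C5CCCCC5)c4c3)n2)cc1`, with bromo in place of formyl on an aromatic carbon, gives 23.3%. The two steps away from the formyl group show a number 22.8 percentage points higher from compound 1 to compound 2 (beyond the scatter) and a number 22.8 percentage points higher from compound 1 to compound 3 (beyond the scatter), both beyond the scatter and both modest. Between the two halogen compounds there is no change at the digits printed from compound 2 to compound 3 (within the scatter). Compound 3 therefore stands level with compound 2 at the top of the three numbers, and compound 1 lies furthest from it.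

Compound 4 `FC(F)(F)c1cccc(-c2cn3ccnc3c(-c3ccc4ncn(C5CCCCC5)c4c3)n2)c1` is the compound now awaiting measurement. Relative to compound 3 the change is 3-(trifluoromethyl)phenyl in place of 4-bromophenyl on an aromatic carbon. Among the measured compounds shown here, no measured step covers a trifluoromethyl group or a change in where the substituent sits on the phenyl ring. For the measured compounds named here, the one step that does bear on the aryl substituent, no change at the digits printed from compound 2 to compound 3 (within the scatter), was within the scatter, while the formyl compound shows that the read-out can drop far. Weighing this, the step of a number 1.3 percentage points lower from compound 3 to compound 4 (within the scatter) is expected to stay within the scatter. In this assay the estimate for compound 4 is 22%, with a range from 5% to 45%.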

Compound 4, a percentage reported as inhibition, at one concentration (the size of the read-out at that concentration, not a potency): 1.55%
The estimate for compound 4 lay 20.5 percentage points above the measured number; the whole stated range lies above it.
By their numbers in this assay, from the lowest: compounds 1 and 4 (each within the scatter of the next); then compounds 2 and 3 (each within the scatter of the next).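

In this assay there is a number 21.8 percentage points lower from compound 3 to compound 4 (beyond the scatter) and likewise a number 21.8 percentage points lower from compound 2 to compound 4 (beyond the scatter) when 3-(trifluoromethyl)phenyl stands on this aromatic carbon of the shared core, so the low reading of compound 1 is no longer confined to a formyl group. Against that formyl compound there is a number 1 percentage points higher from compound 1 to compound 4 (within the scatter) and the two therefore stand together at the low end, while the two halogen compounds stand together at the high end; a low reading thus appears with two quite different aryl groups. The change to compound 4 alters both the substituent and where it sits on the phenyl ring, and these compounds offer no way of telling which of the two carries the drop, nor does any other measurement here account for it.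

On these data alone, what stays open is whether a trifluoromethyl group at the place bromo holds in compound 3 would read with the halogen compounds, and whether bromo at the place trifluoromethyl holds in compound 4 would read low. Also open, as far as these compounds go, is how an amine or a carboxylic acid on this phenyl ring would read, and whether the low readings would persist on other cell lines or at other concentrations.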